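This account rests on a few compounds, and the source may have more. Where it says the series, first, only, none or still open, it means among the compounds named here.

Measured so far:
compound 1, `Cc1ccccc1CN1CCc2c(sc(NC(=O)c3ccccc3Cl)c2C(N)=O)C1`. In a functional assay on MKN-74 cells (Homo sapiens) for antiproliferative activity, with a stated time of 24 h (a lower number here means a stronger inhibitor, a higher number a weaker inhibitor), compound 1 gives > 50000 nM, which is a limit of the assay and not a number.
compound 2, `Cc1ccc(C(=O)Nc2sc3c(c2C(N)=O)CCN(Cc2ccc(Cl)cc2Cl)C3)cc1`. In this assay compound 2 gives 25500 nM.

For the measured compounds named here, compound 1 stands only at the assay limit, (the limit of > 50000 nM in this assay, at which 1 of the 2 values shown sits); no number is known for it, and compound 2 is the one compound with a measured value. Compound 3, `CSc1ccccc1NC(=S)N1CCc2c(sc(NC(=O)c3ccccc3Cl)c2C(N)=O)C1`, differs from compound 1 by a group of 11 heavy atoms (8 carbon, 1 nitrogen, 2 sulfur; one six-membered aromatic ring of carbon only) in place of a group of 8 heavy atoms (8 carbon; one six-membered aromatic ring of carbon only), on an amine nitrogen in a ring. Going by the values given here, no step between measured compounds is available to anchor the size of this change. Compound 3 is expected to remain weak, with a step of an at least 1.2-fold lower number from compound 1 to compound 3 (0.09 log units; that floor lies within the scatter), at most a modest gain and possibly none beyond the scatter. Compound 3 is estimated at 40000 nM, within a range of 12000 nM to 80000 nM.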

Compound 3, half-maximal inhibitory concentration: 13800 nM
Compound 3: the middle estimate sits 2.9-fold (0.46 log units) above what was measured, and the stated range covers the measured number.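

On the amine nitrogen in the ring, the group entering in compound 3 in place of 2-methylbenzyl gives an at least 3.6-fold lower number from compound 1 to compound 3 (0.55 log units; beyond the scatter) in this assay. This shows that a change at this position alone, with the rest of the core of compound 1 unchanged, can move the read-out beyond the scatter. The true size of the step stays open because compound 1 stands at a limit and not at a number: the limit of > 50000 nM in this assay, at which 1 of the 3 values shown sits.

The compounds shown leave open which part of the entering group carries the step. A urea carbonyl in place of the thiocarbonyl, or a methoxy in place of the methylthio group, could separate these parts.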